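Chloro in Place of Fluoro on a Fused-Ring Side Chain

The compounds below may be only part of what the source reports. "The series", "measured", "known", "first", "only" and "open" are said of these compounds alone.

Compound 1 `CC(C)[C@@H](Nc1nc(Cl)nc2c1ncn2[C@H]1[C@H](O)[C@H](O)[C@]2(CF)C[C@H]12)C1CC1` was tested in an ADME assay on Vero 76 cells (Chlorocebus sabaeus) for cytotoxicity, read by microscopy (on this read-out higher numbers stand for lower toxicity in this test and lower numbers for higher toxicity in this test), where compound 1 gives 36000 nM. Among the three compounds examined, this is the only measurement that came back as a number; the two companions returned limits. For compound 2 `O[C@@H]1[C@H](O)[C@@H]2C[C@@H]2[C@H]1n1cnc2c(NCC(C3CC3)C3CC3)nc(Cl)nc21`, the result of > 50000 nM is a limit of this assay rather than a number (the limit of > 50000 nM in this assay, at which 1 of the 3 values shown sits). For compound 3 `CC(C)(C)[C@H](Nc1nc(Cl)nc2c1ncn2[C@H]1[C@H](O)[C@H](O)[C@]2(CO)C[C@H]12)C1CC1`, the result of > 100000 nM is likewise a limit of this assay and not a number (the limit of > 100000 nM in this assay, at which 1 of the 3 values shown sits). Since no two of these compounds differ in a single place, no measured step is available to guide the next change.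

Compound 4 `CC(C)[C@@H](Nc1nc(Cl)nc2c1ncn2[C@H]1[C@H](O)[C@H](O)[C@]2(CCl)C[C@H]12)C1CC1` differs from compound 1 by chloro in place of fluoro on a saturated chain carbon bound to a saturated ring carbon. Within the data shown here, with no measured step to draw on, the step from compound 1 to compound 4 in this assay is expected to stay within the usual scatter, with no clear direction. Compound 4 is therefore estimated at 30000 nM, with a range from 12000 nM to 80000 nM, the expected step being a 1.2-fold lower number from compound 1 to compound 4 (0.08 log units; within the scatter).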

Compound 4, half-maximal cytotoxic concentration: 32000 nM
Beside the measured number, compound 4's estimate is 1.1-fold (0.03 log units) below it, and the stated range covers the measured number.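

Among these compounds, compound 4 gives the first measured step in this set: in this assay, chloro in place of fluoro on a saturated chain carbon bound to a saturated ring carbon amounts to a 1.1-fold lower number from compound 1 to compound 4 (0.05 log units; within the scatter) and so stays within the scatter. The earlier compounds shown here, which differ from one another in more than one place, could not show this, and the pair now shows that at this position, with the rest of compound 1 unchanged, fluoromethyl to chloromethyl leaves the half-maximal cytotoxic concentration without a readable shift. Nothing measured here accounts for that outcome.

On these data alone, whether an aminomethyl group or a carboxylic acid on the same carbon would also stay this close to compound 1 remains open. So does whether the same exchange would behave alike with a longer chain on the side-chain nitrogen of the shared core.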